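Shortening the chain from compound 1 to compound 4

This account rests on a few compounds, and the source may have more. Where it says the series, first, only, none or still open, it means among the compounds named here.

In an ADME assay on a cell-free system (plasma, Homo sapiens) for metabolic stability, read by LC-MS (a lower number here means that the compound disappears faster, a higher number that the compound lasts longer), compound 1 `CCCCCCOC(=O)c1cccc(-c2cc(C(=O)Nc3ccncc3)ccc2CN)c1` gives 0.833 h and compound 3 `NCc1ccc(C(=O)Nc2ccncc2F)cc1-c1cccc(C(=O)OCCO)c1` gives 1.35 h. These two values lie within the scatter of each other, so compound 1 stands level with the only other numerical half-life in the series. Compound 2 `NCc1ccc(C(=O)Nc2ccncc2F)cc1-c1cccc(C(=O)OCC2CCCO2)c1` is reported only as a limit, < 0.0834 h.

Compound 4 `CCCCCOC(=O)c1cccc(-c2cc(C(=O)Nc3ccncc3)ccc2CN)c1` differs from compound 1 by hydrogen in place of methyl on a saturated chain carbon, five bonds along the chain from an oxygen next to a carbonyl group.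

Among the measured compounds shown here, one measured step bears on this change, and only indirectly: an at least 16-fold higher number from compound 2 to compound 3 (1.20 log units; beyond the scatter). That step is large, so the group on the oxygen can matter in this assay. However, it exchanges different groups and was measured on a different core, so it gives no size for the present change. No step beyond the scatter is therefore expected, and no direction is favoured. The estimated step is a 1.1-fold higher number from compound 1 to compound 4 (0.03 log units; within the scatter). The estimate stays close to compound 1 at 0.833 h, with a range kept wide to allow for some sensitivity to the chain. For compound 4 the expected half-life is 0.9 h, with an estimated range of 0.35 h to 2.2 h.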

Compound 4, half-life: 0.967 h
Estimate against measurement, compound 4: 1.1-fold (0.03 log units) below, within the range that was stated.
By their numbers in this assay, from the lowest: compounds 1, 4 and 3 (each within the scatter of the next). At a limit, below all of these: compound 2.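

Among the compounds shown here, the step of a 1.2-fold higher number from compound 1 to compound 4 (0.06 log units; within the scatter) is the first measured change at this position, on a saturated chain carbon, five bonds along the chain from an oxygen next to a carbonyl group, and the first pair that differs only in the length of this chain. In this assay, for the compounds shown here, hydrogen in place of methyl at this place therefore leaves the half-life level on the core of compound 1, whereas the only earlier step, an at least 16-fold higher number from compound 2 to compound 3 (1.20 log units; beyond the scatter), exchanged other groups on a different core and showed only that the group on the oxygen can matter. No measurement shown here gives a reason why this position tolerates the change, so the pair stands as an observation without a cause.

From the compounds shown here alone, whether a longer chain, or a shorter one such as ethyl or propyl, would stay level with compound 1 remains open, as this single step covers only the loss of one methyl at the chain end. Also open, going by these compounds, is whether an amine or a carboxylic acid at the end of the chain would shift the half-life beyond the scatter, and whether the level result would carry over to the core of compound 3.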